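The compounds below may be only part of what the source reports. "The series", "measured", "known", "first", "only" and "open" are said of these compounds alone.

Measured compounds in a toxicity assay on Vero cells (Chlorocebus sabaeus) for cytotoxicity; on this read-out lower numbers stand for higher toxicity in this test and higher numbers for lower toxicity in this test:
Compound 1, `COc1nc(-c2ccccc2F)ccc1[C@@H](c1ccccc1)[C@@](O)(CCN(C)C)c1cccc2ccccc12`, gives > 50 ug/mL, which is a limit of the assay rather than a number.
Compound 2, `COc1ncc(-c2ccccc2)cc1[C@@H](c1ccccc1)[C@@](O)(CCN(C)C)c1cccc(F)c1F`, gives > 50 ug/mL, likewise a limit of the assay.

Compound 1 therefore stands only at a limit of this assay, and the same is true of the other value shown: the limit of > 50 ug/mL in this assay, at which 2 of the 2 values shown sit. Within the data shown here, no pair of measured compounds that differ in one place is available, so no measured step can be drawn on.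

Compound 3, `COc1nc(-c2ccc(C#N)cc2)ccc1[C@@H](c1ccccc1)[C@@](O)(CCN(C)C)c1cccc2ccccc12`, is not yet measured in this assay. Compared with compound 1 it carries 4-cyanophenyl in place of 2-fluorophenyl on an aromatic carbon.

With both measured values sitting at the limit, nothing points to a move beyond the usual scatter, and compound 3 is expected to remain at the limit as well. The expected step of a number no higher from compound 1 to compound 3 (the limit leaves the size open) is none beyond the scatter. For compound 3 the estimate in this assay is 50 ug/mL, with a range from 25 ug/mL to 100 ug/mL, most likely reported again as a limit.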

Compound 3, half-maximal cytotoxic concentration: > 50 ug/mL
Compound 3: no number, only a limit (the forecaster's own chance of this, stated with the estimate: 85%); the middle value sits exactly at the limit.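

In this assay compound 3 gives > 50 ug/mL, a limit of the assay and not a number. Among these compounds, compound 1 also stands at a limit, so no step between compound 1 and compound 3 can be read. The compounds shown leave open whether 4-cyanophenyl in place of 2-fluorophenyl alters cytotoxicity at all.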